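From benzyl to 4-methylbenzyl on compound 1

This account rests on a few compounds, and the source may have more. Where it says the series, first, only, none or still open, it means among the compounds named here.

In a functional assay on RS4-11 cells (Homo sapiens) for inhibition, read by CCK-8 assay, with a stated time of 48 h, tested at 20 uM (on this read-out lower numbers stand for less inhibition of growth and higher numbers for more inhibition of growth at the one concentration tested), compound 1 (`Cc1ccc(S(=O)(=O)Oc2ccccc2/C=C(\C#N)C(=O)Nc2nnc(Cc3ccccc3)s2)cc1`) gives 69%, compound 3 (`N#C/C(=C\c1ccccc1OS(=O)(=O)c1ccc(F)cc1)C(=O)Nc1nnc(Cc2ccccc2)s1`) gives 69% and compound 2 (`N#C/C(=C\c1ccccc1OS(=O)(=O)c1ccccc1[N+](=O)[O-])C(=O)Nc1nnc(Cc2ccccc2)s1`) gives 71%, so all three stand level within the scatter. Compound 4 (`Cc1ccc(Cc2nnc(NC(=O)/C(C#N)=C/c3ccccc3OS(=O)(=O)c3ccc(C)cc3)s2)cc1`) turns the benzyl of compound 1 into 4-methylbenzyl: methyl in place of hydrogen on an aromatic carbon. Two measured steps give the nearest guide, a number 2 percentage points higher from compound 1 to compound 2 (within the scatter) and no change at the digits printed from compound 1 to compound 3 (within the scatter). Both alter the group on the sulfonyl sulfur and leave the benzyl untouched, so they bear on this change only indirectly. Neither exceeds the scatter, and no step beyond the scatter is expected here. The expected step is a number 1 percentage points higher from compound 1 to compound 4 (within the scatter). For compound 4 the estimate is 70%, within an expected range from 57% to 83%.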

Compound 4, percent growth inhibition at one concentration: 66%
The estimate for compound 4 lay 4 percentage points above the measured number, and the stated range covers the measured number.
By their numbers in this assay, from the lowest: compounds 4, 1, 3 and 2 (each within the scatter of the next).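

Among the compounds shown here, compounds 1, 2 and 3 all carry the same benzyl and differ only in the group on the sulfonyl sulfur, so compound 4 brings the only change at the benzyl end. In this assay, adding methyl there gives a number 3 percentage points lower from compound 1 to compound 4 (within the scatter) and so no change that can be told from the scatter. This position therefore tolerates one added methyl, para to a large group, in this single-concentration test. On these data alone, whether a larger or charged group here, such as an amine or a carboxylic acid, would also leave growth inhibition level stays open. Nothing available explains the result for compound 4.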